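Adding a methoxy to the anilino ring of a thiazole amide

This account rests on a few compounds, and the source may have more. Where it says the series, first, only, none or still open, it means among the compounds named here.

Of the compounds shown here, two have been tested in a functional assay on SNB-19 cells (Homo sapiens) for antiproliferative activity, read by sulforhodamine B assay, with a stated time of 48 h; on this read-out higher numbers stand for weaker inhibition of growth and lower numbers for stronger inhibition of growth. Among the compounds with values here, compound 1 `Cc1nc(SCC(=O)Nc2nc(-c3ccc(Cl)cc3)cs2)n(Nc2ccccc2)c1C` is the only one with an actual number: in this assay compound 1 gives 24600 nM. Compound 2 `Cc1ccc(Nn2c(SCC(=O)Nc3nc(-c4ccccc4)cs3)nc(C)c2C)cc1` carries a methyl on its anilino ring and lacks the chloro of compound 1; in this assay compound 2 reaches only > 100000 nM, which is a limit of the assay and not a number. So compound 1 stands alone on the measured side, while the one other value sits at the limit (the limit of > 100000 nM in this assay, at which 1 of the 2 values shown sits).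

Compound 3 `COc1ccc(Nn2c(SCC(=O)Nc3nc(-c4ccc(Cl)cc4)cs3)nc(C)c2C)cc1` differs from compound 1 in one place: methoxy in place of hydrogen on an aromatic carbon. Within the data shown here, no measured pair in this set isolates that single change, so the size of the step rests on expectation alone. The step from compound 1 to compound 3 is expected to be modest and toward weaker inhibition, a 1.6-fold higher number from compound 1 to compound 3 (0.21 log units; within the scatter), because substitution on the anilino ring in compound 2 coincides with a value at the limit (the limit of > 100000 nM in this assay, at which 1 of the 2 values shown sits). In this assay compound 3 is therefore estimated at 40000 nM, within a range of 15000 nM to 100000 nM.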

Compound 3, concentration for total growth inhibition: > 100000 nM
Compound 3 was reported as a limit; the forecaster's own chance of this, stated with the estimate: 35%; middle value at least 2.5-fold (0.39 log units) from the limit.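

In this assay, within the data shown here, putting a methoxy in place of hydrogen on the anilino ring gives an at least 4.0-fold higher number from compound 1 to compound 3 (0.60 log units; beyond the scatter), the first step in this set that changes only one place and can be read on its own. The value of compound 3, > 100000 nM, is a limit of the assay and not a number. Changing phenyl to 4-methoxyphenyl at this position, on an aromatic carbon para to a large group, therefore takes the chloro-bearing compound 1 from a measured value to the limit, and the limit now holds most of the values in this small set: the limit of > 100000 nM in this assay, at which 2 of the 3 values shown sit.

The compounds shown leave open whether the drop belongs to the methoxy itself or to any group at this position, since compound 2 differs from compound 1 in two places and cannot settle the point. A fluorine, a hydroxyl or an amine on the same aromatic carbon would show whether any substituent there can keep the growth inhibition of compound 1.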